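The source may report more compounds than this note shows. Statements on the series, on what has been measured and on what is new or still open speak of the compounds shown alone.

Of the compounds shown here, three sharing one core have been measured in a functional assay on CHO-K1 cells for antagonist activity at transient receptor potential cation channel subfamily V member 1 (Homo sapiens), read by FLIPR; a higher number here means a weaker inhibitor, a lower number a stronger inhibitor. Compound 1 `CC(C(=O)NCc1ccc(C(F)(F)F)nc1N1CCN(C)CC1)c1ccc(NS(C)(=O)=O)c(F)c1` carries a methyl group on the amine nitrogen in the ring; in this assay compound 1 gives 146 nM. Compound 2 `CC(C(=O)NCc1ccc(C(F)(F)F)nc1N1CCN(C2CCCCC2)CC1)c1ccc(NS(C)(=O)=O)c(F)c1` carries a cyclohexyl group at that position, and compound 2 gives 21.6 nM. Compound 3 `COc1ccc(N2CCN(c3nc(C(F)(F)F)ccc3CNC(=O)C(C)c3ccc(NS(C)(=O)=O)c(F)c3)CC2)cc1` carries a 4-methoxyphenyl group there, and compound 3 gives 2.5 nM, the lowest number of the three, so compound 3 is the strongest inhibitor among them.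

The steps between these compounds all lie beyond the scatter: a 6.8-fold lower number from compound 1 to compound 2 (0.83 log units; beyond the scatter), a 58-fold lower number from compound 1 to compound 3 (1.77 log units; beyond the scatter) and an 8.6-fold lower number from compound 2 to compound 3 (0.94 log units; beyond the scatter). Each shows that the group on the amine nitrogen in the ring matters, and that a ring group, especially an aromatic one, gives the lower number.

Compound 4 `CC(C(=O)NCc1ccc(C(F)(F)F)nc1N1CCN(c2ncccc2Cl)CC1)c1ccc(NS(C)(=O)=O)c(F)c1` is the next compound. The change is 3-chloropyridin-2-yl in place of 4-methoxyphenyl on an amine nitrogen in a ring. Both groups are six-membered aromatic rings attached at the same place, so the aromatic character that separates compound 3 from compound 2 and compound 1 is kept. Within the data shown here, no measured step shows the effect of a ring nitrogen or a chlorine at this position, so the estimate stays close to compound 3 with some allowance for a weaker outcome.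

Compound 4 is therefore expected to give 4 nM, between 1.5 nM and 12 nM. This expectation amounts to a 1.6-fold higher number from compound 3 to compound 4 (0.20 log units; within the scatter), a step estimated to stay within the scatter.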

Compound 4, inhibition constant: 2.1 nM
For compound 4 the middle estimate is 1.9-fold (0.28 log units) above the measured one; measured number inside the range.
By their numbers in this assay, from the lowest: compounds 4 and 3 (each within the scatter of the next); then compound 2; then compound 1.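

Placing 3-chloropyridin-2-yl on the amine nitrogen in the ring in place of 4-methoxyphenyl, in this assay, gives a 1.2-fold lower number from compound 3 to compound 4 (0.08 log units; within the scatter), so this position accepts a second aromatic ring that carries a ring nitrogen and a chlorine rather than a methoxy group, with no change beyond the scatter. The new group also keeps its distance from the two non-aromatic groups, with a 10-fold lower number from compound 2 to compound 4 (1.01 log units; beyond the scatter) against cyclohexyl and a 70-fold lower number from compound 1 to compound 4 (1.84 log units; beyond the scatter) against methyl, so the link between an aromatic ring at this position and a lower number now rests on two different rings, those of compound 3 and compound 4, and none of the four compounds goes against it. No measurement is available that explains why these two aromatic groups give such similar numbers.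

Going by these compounds, the ring nitrogen and the chlorine enter together, so their separate contributions remain unknown, and a plain pyridin-2-yl or a 3-chlorophenyl group would be needed to pull them apart. On these data alone, it also remains open how this position would respond to a benzyl group, which sets a carbon atom between the aromatic ring and the amine nitrogen.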